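From a Methyl to a Bromo Substituent

The source may report more compounds than this note shows. Statements on the series, on what has been measured and on what is new or still open speak of the compounds shown alone.

For the measured compounds named here, compound 1 `Cc1ccccc1C1N[C@H](C(=O)O)CS1` is the only compound in this set with a number in a physicochemical assay, with a stated time of 50 min; on this read-out lower numbers stand for stronger inhibition and higher numbers for weaker inhibition: there compound 1 gives 39000 nM. Compound 2 `O=C(O)[C@@H]1CSC(c2ccc([N+](=O)[O-])cc2)N1` was also examined in this assay, where compound 2 gives "nd(insoluble)" (no result reported). No figure is reported for compound 2, so compound 1 stands alone as the single measured point.

Compound 3 `O=C(O)[C@@H]1CSC(c2ccccc2Br)N1` differs from compound 1 in one place: bromo in place of methyl on an aromatic carbon. Both groups count one heavy atom, carry no ring, no hydrogen-bond donor or acceptor and no net charge, and the change sits on the aromatic carbon ortho to a group of 8 heavy atoms. Going by the values given here, with no second measured pair to draw on, any expectation rests on compound 1 alone. The step from compound 1 to compound 3 is expected to be small, and most likely to stay within the usual scatter, as a 1.3-fold lower number from compound 1 to compound 3 (0.11 log units; within the scatter) expresses. For compound 3 the estimate in this assay is therefore 30000 nM, with a range from 10000 nM to 90000 nM.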

Compound 3, half-maximal inhibitory concentration: 37700 nM
For compound 3 the middle estimate is 1.3-fold (0.10 log units) below the measured one; measured number inside the range.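

In this assay, bromo in place of methyl on an aromatic carbon, ortho to a group of 8 heavy atoms, gives a 1.0-fold lower number from compound 1 to compound 3 (0.01 log units; within the scatter), so this exchange leaves the read-out within the scatter. Where compound 1 alone had offered a single number, the pair now shows that methyl and bromo at this place can be exchanged without a change that can be told from the scatter. Nothing measured here offers an explanation for this match. The compounds shown leave open whether an amine, a carboxylic acid or a longer chain at this place would also stay within the scatter of compound 1. Compound 2 has no number in this assay, so the nitro group it carries remains unread.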